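A Sulfonyl Swap Measured Only at a Limit

The source may report more compounds than this note shows. Statements on the series, on what has been measured and on what is new or still open speak of the compounds shown alone.

Measured so far in an ADME assay on HEK293 cells (Homo sapiens) for cytotoxicity, read by resazurin assay, with a stated time of 48 h; on this read-out lower numbers stand for higher toxicity in this test and higher numbers for lower toxicity in this test:
Compound 1 `CS(=O)(=O)Nc1ccc(-c2nc3ccccc3o2)cc1`: > 100000 nM (a limit)
Compound 2 `O=S(=O)(Nc1ccc(-c2nc3ccccc3o2)cc1)c1ccc(F)cc1`: > 100000 nM (a limit)

Compound 2 has no number to stand on, only a limit. In this assay compound 2 gives > 100000 nM, and this is a limit of the assay.

Compound 3 `Cc1ccccc1S(=O)(=O)Nc1ccc(-c2nc3ccccc3o2)cc1` has yet to be measured. It carries 2-methylphenyl in place of 4-fluorophenyl on a sulfonyl sulfur, and the counted difference is 2-methylphenyl in place of 4-fluorophenyl on a sulfonyl sulfur.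

For the measured compounds named here, one measured step bears on this change, also made on a sulfonyl sulfur: a step that the two limits leave unreadable from compound 1 to compound 2. Its size therefore offers no guide. What remains is the limit of > 100000 nM in this assay, at which 2 of the 2 values shown sit.

Resting on compound 2 and (the limit of > 100000 nM in this assay, at which 2 of the 2 values shown sit), no step beyond the usual scatter is expected in this assay, and no direction is expected either. The assay is expected to report only a limit again for the new compound.

The estimated change is a number no higher from compound 2 to compound 3 (the limit leaves the size open).

For compound 3 the expected value is 100000 nM, with an estimated range of 40000 nM to 200000 nM.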

Compound 3, half-maximal cytotoxic concentration: > 100000 nM
Compound 3 ended at the assay's limit; the forecaster's own chance of this, stated with the estimate: 85%; the middle value lies on the limit itself.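

Compound 3 gives > 100000 nM in this assay, and this is a limit of the assay, not a number. No step among compound 1, compound 2 and compound 3 can be read: the limit of > 100000 nM in this assay, at which 3 of the 3 values shown sit.

The compounds shown leave open how far each lies from that limit, and whether any group on the sulfonyl sulfur changes this read-out at all.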